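Adding Methoxy to Compound 2

This account rests on a few compounds, and the source may have more. Where it says the series, first, only, none or still open, it means among the compounds named here.

In a functional assay on HeLa cells (Homo sapiens) for antiproliferative activity, read by MTT assay, with a stated time of 48 h (a higher number here means a weaker inhibitor, a lower number a stronger inhibitor), compound 1 `Cc1ccc2[nH]c(-c3cn(-c4ccccc4)nc3-c3ccccc3)nc2c1` gives 6560 nM, and compound 3 `Clc1ccc(-c2nn(-c3ccccc3)cc2-c2nc3cc(Br)ccc3[nH]2)cc1` gives 2160 nM. Compound 2 `Cc1cc2nc(-c3cn(-c4ccccc4)nc3-c3ccccc3)[nH]c2cc1C` gives 41500 nM, the highest of the three numbers. Compound 4 `COc1ccc(-c2nn(-c3ccccc3)cc2-c2nc3cc(C)c(C)cc3[nH]2)cc1` departs from it through methoxy in place of hydrogen on an aromatic carbon, phenyl to 4-methoxyphenyl: methoxy in place of hydrogen on an aromatic carbon. Going by the values given here, no measured step shows this change directly. Among the compounds with values here, the only step available, a 6.3-fold higher number from compound 1 to compound 2 (0.80 log units; beyond the scatter), is a modest one and concerns methyl in place of hydrogen on an aromatic carbon, so it gives a rough sense of size and no direction for methoxy. Direction rests loosely on compound 3, whose 2160 nM is a lower number than that of compound 2, although the two differ in more than one place. A modest move toward a lower number is therefore expected, namely a 2.8-fold lower number from compound 2 to compound 4 (0.44 log units; beyond the scatter). For compound 4 the estimated value is 15000 nM, with an expected range from 4000 nM to 50000 nM.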

Compound 4, half-maximal inhibitory concentration: 8930 nM
The estimate for compound 4 lay 1.7-fold (0.23 log units) above the measured number; low and high end bracket the measured number.
By their numbers in this assay, from the lowest: compound 3; then compounds 1 and 4 (each within the scatter of the next); then compound 2.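

In this assay, going by these compounds alone, the change from phenyl to 4-methoxyphenyl gives a 4.6-fold lower number from compound 2 to compound 4 (0.67 log units; beyond the scatter) and so provides the first direct reading of methoxy on an aromatic carbon, para to a large group. Within the data shown here, this modest step runs toward a lower number, whereas the only earlier step, a 6.3-fold higher number from compound 1 to compound 2 (0.80 log units; beyond the scatter), concerned methyl in place of hydrogen at a different place and ran toward a higher one. No measurement shown accounts for the effect of methoxy at this position.

The compounds shown leave open whether a hydroxyl, an amine or a longer chain such as ethoxy at the same position would move the number in the same direction. They also leave open whether methoxy would produce a step of similar size on the core of compound 1.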